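Swapping a pyrazine for a pyridine on a urea

The compounds below may be only part of what the source reports. "The series", "measured", "known", "first", "only" and "open" are said of these compounds alone.

Values measured so far in a physicochemical assay for lipophilicity, read by HPLC, measured as octanol-water partition, at pH 7.2 (a lower number here means a more polar compound, a higher number a more lipophilic compound), are these:
Compound 1 `N#Cc1ccc(NC(=O)Nc2ccc(F)c(C(F)(F)F)c2)cc1` gives 3.8 (the highest)
Compound 2 `O=C(Nc1cccc(C(=O)O)c1)Nc1ccc(F)c(C(F)(F)F)c1` gives 1.6 (the lowest)
Compound 3 `O=C(Nc1ccc(F)c(C(F)(F)F)c1)Nc1cnccn1` gives 3 (the middle)

Compound 3 (3) holds the second place of the three. Compound 1 stands above it and compound 2 stands below it, and both gaps lie beyond the usual scatter of repeated measurements, with the gap to compound 2 the wider one.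

The next compound to be measured is compound 4 `O=C(Nc1ccc(F)c(C(F)(F)F)c1)Nc1ccccn1`, which has pyridin-2-yl in place of pyrazin-2-yl on an amide-type nitrogen. The rest of the molecule stays the same.

Among the compounds with values here, no two measured compounds differ in one place only, so the data hold no direct precedent for this swap. A moderate upward step in this assay is still expected, probably just beyond the scatter. Compound 1 (3.8) serves as a rough guide to the top of the range seen so far, and compound 4 is not expected to pass it by much. The estimated step runs (a number 0.50 log units higher from compound 3 to compound 4 (beyond the scatter)). In this assay compound 4 is expected at 3.5 with an estimated range of 3.1 to 3.9 (a rough expectation).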

Compound 4, distribution coefficient: 3.7
Compound 4: the middle estimate sits 0.20 log units below what was measured; the measured number falls inside the stated range.
By their numbers in this assay, from the lowest: compound 2; then compound 3; then compounds 4 and 1 (each within the scatter of the next).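

Within the data shown here, this is the first pair of compounds here that differ in one place only, which lets a single change be read on its own in this assay: with pyridin-2-yl in place of pyrazin-2-yl on an amide-type nitrogen, the step is (a number 0.70 log units higher from compound 3 to compound 4 (beyond the scatter)). The two groups are close relatives by count, since each is a six-membered aromatic ring of 6 heavy atoms, and the entering ring has 1 hetero atom and 1 hydrogen-bond acceptor where the leaving ring has 2 of each, yet that small difference is enough to carry the number past the usual scatter. Nothing measured here explains the size of this step, which stands as an observation only.

The compounds shown leave open what a plain phenyl or a pyrimidin-2-yl would give on the same amide-type nitrogen, which would show whether the numbers follow the count of ring nitrogens or depend on which ring is present. This is also a single pair, and whether the same swap gives a similar step when the rest of the molecule carries a different group, such as an amine or a carboxylic acid, remains an open question.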